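Methoxy added to the benzamide ring of compound 2

The source may hold more compounds than are shown below. What is called first, only, known or untested is meant among the compounds shown, and "the series" means these compounds.

Compound 2 `O=C(COc1ccc2c(=O)ccoc2c1)Nc1cccc(NC(=O)c2ccccc2)c1` carries an unsubstituted benzamide on the shared core. Among the measured compounds shown here, in an assay on isolated protein for inhibition of Rho-associated protein kinase 2 (Homo sapiens), read by scintillation counting, radiometric assay and 33P incorporation, with a stated time of 40 min, in the presence of a further agent that is not named here (on this read-out lower numbers stand for stronger inhibition and higher numbers for weaker inhibition), compound 2 gives 16 nM, the lowest of the two numbers so far. Compound 1 `CN(C)c1ccc(C(=O)Nc2cccc(NC(=O)COc3ccc4c(c3)OCCC4=O)c2)cc1` differs from it in more than one place, in the core as well as in the dimethylamino group on the benzamide ring; in this assay compound 1 gives 85 nM, and the gap between the two numbers lies beyond the scatter, but with two changes at once nothing can be assigned to either of them. Compound 3 `COc1ccc(C(=O)Nc2cccc(NC(=O)COc3ccc4c(=O)ccoc4c3)c2)cc1` is the next case: methoxy in place of hydrogen on an aromatic carbon. For the measured compounds named here, no comparison between measured compounds isolates this change on its own. Going by the values given here, the only measured compound that bears a group on the benzamide ring, compound 1, sits higher, yet its second difference leaves that open. The step of a 1.6-fold higher number from compound 2 to compound 3 (0.19 log units; within the scatter) is expected to be small, a mild loss at most, and may well stay within the scatter. For compound 3 in this assay the estimate is 25 nM, with a range from 8 nM to 80 nM.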

Compound 3, half-maximal inhibitory concentration: 7 nM
Compound 3: middle estimate off by 3.6-fold (0.55 log units), on the high side, and the stated range ends above it.
By their numbers in this assay, from the lowest: compound 3; then compound 2; then compound 1.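

In this assay, methoxy in place of hydrogen on the benzamide ring, para to a large group, gives a 2.3-fold lower number from compound 2 to compound 3 (0.36 log units; beyond the scatter). Among the compounds shown here, this is the first comparison that isolates a single change, and it shows that this carbon of the benzamide ring accepts a methoxy group with a modest gain rather than a loss. No measurement shown gives a reason for that gain, so it cannot be tied to any property of the methoxy group.

Going by these compounds, whether the gain is particular to methoxy remains open, since only hydrogen and methoxy can be compared at this carbon on the shared core; a fluorine, a hydroxyl, an ethoxy group, a primary amine or a carboxylic acid there would show how far the trend extends. The dimethylamino group of compound 1 also remains unresolved. That compound differs in its core as well, and the same group on the core of compound 2 would separate the two changes.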